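This account rests on a few compounds, and the source may have more. Where it says the series, first, only, none or still open, it means among the compounds named here.

Of the compounds shown here, three built on one shared core have so far been tested in a functional assay on PC-6 cells (Homo sapiens) for cytotoxicity, read by MTT assay, with a stated time of 3 days; on this read-out lower numbers stand for stronger inhibition and higher numbers for weaker inhibition. Compound 1 `CN(C)S(=O)(=O)c1ccc(/C=N/Nc2ncnc3sc(C(C)(C)C)cc23)cc1` gives 2.12 ug/mL, the highest number of the three. Compound 2 `CN1Cc2ccc(/C=N/Nc3ncnc4sc(C(C)(C)C)cc34)cc2C1` gives 0.05 ug/mL, and compound 3 `CN(C)Cc1cccc(/C=N/Nc2ncnc3sc(C(C)(C)C)cc23)c1` gives 0.598 ug/mL; each of these lies beyond the scatter below compound 1. Compound 4 `CC(C)(C)c1cc2c(N/N=C/c3ccccc3)ncnc2s1` has not yet been measured. It differs from compound 1 in a single place: hydrogen in place of dimethylsulfamoyl on an aromatic carbon. For the measured compounds named here, no measured pair shows this particular change, so its effect is not known from the data. Given that the two lower numbers come from quite different groups, the step from compound 1 is expected to be small, a 1.4-fold lower number from compound 1 to compound 4 (0.15 log units; within the scatter), possibly not beyond the scatter. Compound 4 is therefore expected to give about 1.5 ug/mL, with a likely range from 0.3 ug/mL to 6 ug/mL.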

Compound 4, half-maximal inhibitory concentration: 6.54 ug/mL
Compound 4: the middle estimate sits 4.4-fold (0.64 log units) below what was measured, outside the stated range (above it).
By their numbers in this assay, from the lowest: compound 2; then compound 3; then compound 1; then compound 4.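

Taking the substituent off the aromatic ring raises the number in both comparisons that can be read. Replacing dimethylsulfamoyl with hydrogen gives a 3.1-fold higher number from compound 1 to compound 4 (0.49 log units; beyond the scatter), a modest step, while replacing (dimethylamino)methyl with hydrogen gives an 11-fold higher number from compound 3 to compound 4 (1.04 log units; beyond the scatter), a large one. Each of these two groups therefore gives a lower number than hydrogen does, although they share little beyond their attachment to the ring. Nothing available explains why either group lowers the number.

As far as these compounds go, whether a simple methyl, a carboxylic acid or a primary amine on the same carbon would also lower the number remains open.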